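Methoxy to propoxy: working notes on compound 4

A few compounds are considered here, and "the series" means these few. Any claim that something is new, unique, unknown or untested is made for them only; others in the source may bear on it.

Compound 1 `CCC(=O)Nc1cc(C(=O)Nc2ccc(N3CCN(C)CC3)cc2)ccc1OC` gives > 200000 nM (a limit)
Compound 2 `CCC(=O)Nc1cc(C(=O)Nc2ccc(OC)cc2)ccc1OC` gives 109000 nM
Compound 3 `CCC(=O)Nc1cc(C(=O)Nn2c(C)nnc2S)ccc1OC` gives > 200000 nM (a limit)

Within the data shown here, in a toxicity assay on Huh-7.5 cells (Homo sapiens) for inhibition, read by MTT assay, with a stated time of 96 h (a higher number here means that more compound is tolerated, a lower number that less compound is tolerated), compound 2 holds the only number, while compound 1 and compound 3 both sit at a limit (the limit of > 200000 nM in this assay, at which 2 of the 3 values shown sit).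

Compound 4 `CCCOc1ccc(C(=O)Nc2ccc(OC)cc2)cc1NC(=O)CC` differs from compound 2 by ethyl in place of hydrogen on a saturated chain carbon bound to an oxygen on an aromatic ring (methoxy to propoxy, with ethyl in place of hydrogen on a saturated chain carbon bound to an oxygen on an aromatic ring).

Among the measured compounds shown here, two measured steps touch compound 2: an at least 1.8-fold lower number from compound 1 to compound 2 (0.26 log units; that floor lies within the scatter) and an at least 1.8-fold higher number from compound 2 to compound 3 (0.26 log units; that floor lies within the scatter) (both floors within the scatter). Both change another place, so neither bears directly on this change. In this assay no step beyond the scatter is expected, and a 1.1-fold lower number from compound 2 to compound 4 (0.06 log units; within the scatter) is the estimated step, with no firm direction. For compound 4 the expected value is 95000 nM (estimated range 45000 nM to 200000 nM).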

Compound 4, half-maximal cytotoxic concentration: 106000 nM
For compound 4 the middle estimate is 1.1-fold (0.05 log units) below the measured one; the measured number falls inside the stated range.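

In this assay, methoxy to propoxy gives a 1.0-fold lower number from compound 2 to compound 4 (0.01 log units; within the scatter), so at this position the added ethyl does not separate the two compounds. Unlike the steps touching compound 1 and compound 3, this step joins two numbers rather than a number and a limit: the limit of > 200000 nM in this assay, at which 2 of the 4 values shown sit.

Going by these compounds, whether a longer chain such as hexyloxy, or an amine or a carboxylic acid at the end of the propoxy chain, would read the same stays open. So does whether propoxy reads the same alongside the 4-methylpiperazin-1-yl group of compound 1.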